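A few compounds are considered here, and "the series" means these few. Any claim that something is new, unique, unknown or untested is made for them only; others in the source may bear on it.

Measured compounds:
Compound 1 `NS(=O)(=O)c1cc(-c2nnc(Cn3cc(-c4ccccc4)nn3)o2)c(Cl)cc1SCc1ccccc1` gives 170000 nM in a functional assay on MCF7 cells (Homo sapiens) for cytotoxicity, read by MTT assay, with a stated time of 72 h; on this read-out lower numbers stand for stronger inhibition and higher numbers for weaker inhibition.
Compound 2 `NS(=O)(=O)c1cc(-c2nnc(CNS(=O)(=O)c3ccc(Cl)cc3)o2)c(Cl)cc1SCc1ccccc1` gives 30000 nM in this assay.

Compound 2 holds the lowest of the two numbers, set apart from compound 1 by a 5.7-fold lower number from compound 1 to compound 2 (0.75 log units; beyond the scatter). Compound 3 `NS(=O)(=O)c1cc(-c2nnc(/C=C/c3c(Cl)cccc3Cl)o2)c(Cl)cc1SCc1ccccc1` carries the change (2-(2,6-dichlorophenyl)ethenyl in place of (((4-chlorophenyl)sulfonyl)amino)methyl on an aromatic carbon). Among the measured compounds shown here, no measured step covers this exchange directly; the only step known, from compound 1 to compound 2, shows that swapping the group on the carbon bound to the core moves this assay by a modest amount, and compound 3 drops the hydrogen-bond donor and the acceptors that compound 2 brought in, as compound 1 lacked them. The expectation for compound 3 is therefore a step back toward the number of compound 1, estimated as a 3.3-fold higher number from compound 2 to compound 3 (0.52 log units; beyond the scatter). Compound 3 is thus expected to give 100000 nM, with a range from 30000 nM to 300000 nM.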

Compound 3, half-maximal inhibitory concentration: 29000 nM
Compound 3: the middle estimate sits 3.4-fold (0.54 log units) above what was measured, outside the stated range (below it).
By their numbers in this assay, from the lowest: compounds 3 and 2 (each within the scatter of the next); then compound 1.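

In this assay, the 2-(2,6-dichlorophenyl)ethenyl and (((4-chlorophenyl)sulfonyl)amino)methyl groups on this aromatic carbon of the five-membered ring are not told apart, with a 1.0-fold lower number from compound 2 to compound 3 (0.01 log units; within the scatter). The hydrogen-bond donor and acceptors of the leaving group are therefore not needed for compound 3 to match compound 2 in this pair, and replacing (4-phenyl-1H-1,2,3-triazol-1-yl)methyl also gives a 5.9-fold lower number from compound 1 to compound 3 (0.77 log units; beyond the scatter), so the step away from that group is no longer tied to the sulfonyl-bearing group alone. No supporting measurement bears on the reason for these numbers.

Open, going by these compounds, is whether the chlorine atoms matter, as a plain 2-phenylethenyl group would show. Also open, on these data alone, is how an amine or a carboxylic acid on this aromatic carbon would compare with these groups.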